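The source may report more compounds than this note shows. Statements on the series, on what has been measured and on what is new or still open speak of the compounds shown alone.

Compound 1 `Cc1ncnc2c1c(-c1cccs1)cn2[C@@H]1O[C@H](CO)[C@@H](O)[C@H]1O`: in a functional assay on CEM-DNR-bulk cells (Homo sapiens), read by MTT assay, with a stated time of 72 h (a higher number here means a weaker inhibitor, a lower number a stronger inhibitor), compound 1 gives > 20000 nM, a limit of the assay.
Compound 2 `CNc1ncnc2c1c(-c1cccs1)cn2[C@@H]1O[C@H](CO)[C@@H](O)[C@H]1O`: in this assay compound 2 gives > 20000 nM, also a limit.

Among the measured compounds shown here, compound 1 thus stands at a limit rather than at a measured number, and the only other known value shares that position (the limit of > 20000 nM in this assay, at which 2 of the 2 values shown sit). Compound 3 `Cc1ncnc2c1c(I)cn2[C@@H]1O[C@H](CO)[C@@H](O)[C@H]1O` differs from compound 1 by iodo in place of thiophen-2-yl on an aromatic carbon. For the measured compounds named here, the single measured step, a step that the two limits leave unreadable from compound 1 to compound 2, concerns a different group and has no readable size, so nothing measured bears on this change and no direction or size in this assay can be anchored. Starting from compound 1 at the limit, compound 3 is expected to give about 30000 nM, between 8000 nM and 120000 nM, which means an expected step that the limit leaves unreadable from compound 1 to compound 3.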

Compound 3, half-maximal inhibitory concentration: 12600 nM
Compound 3: the middle estimate sits 2.4-fold (0.38 log units) above what was measured; low and high end bracket the measured number.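

Swapping thiophen-2-yl for iodo, a single atom in place of a five-membered aromatic ring, gives in this assay an at least 1.5-fold lower number from compound 1 to compound 3 (0.20 log units; that floor lies within the scatter). Among the compounds shown here, this is the first change at this position with a readable step, although its floor does not yet show a real gain. Compound 3 is also the only compound shown with a measured number rather than a limit: the limit of > 20000 nM in this assay, at which 2 of the 3 values shown sit.

On these data alone, whether a smaller chloro group, a phenyl ring or an amine at this position would lower the number further stays open. So does whether methylamino in place of methyl would matter once iodo is present.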